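The source may report more compounds than this note shows. Statements on the series, on what has been measured and on what is new or still open speak of the compounds shown alone.

Compound 3 `CCc1cccc(CC)c1-n1nncc1CN1C(=O)C2(C(C#N)=C(N)Oc3c(N)cc4nc5ccccc5nc4c32)c2ccccc21` carries a 2,6-diethylphenyl on an aromatic nitrogen of the shared core. In a functional assay on A549 cells (Homo sapiens) for antiproliferative activity, read by MTT assay, with a stated time of 48 h (a lower number here means a stronger inhibitor, a higher number a weaker inhibitor), compound 3 reaches only the limit of the assay, > 50000 nM. Two companions share that core. Compound 1 `Cc1ccccc1-n1nncc1CN1C(=O)C2(C(C#N)=C(N)Oc3c(N)cc4nc5ccccc5nc4c32)c2ccccc21` gives 31700 nM in this assay. Compound 2 `CC(=O)Nc1ccc(-n2nncc2CN2C(=O)C3(C(C#N)=C(N)Oc4c(N)cc5nc6ccccc6nc5c43)c3ccccc32)cc1` likewise sits at the assay limit, > 50000 nM. The measured steps are an at least 1.5-fold higher number from compound 1 to compound 2 (0.19 log units; that floor lies within the scatter) and an at least 1.5-fold higher number from compound 1 to compound 3 (0.19 log units; that floor lies within the scatter), both floors that lie within the scatter; the step that the two limits leave unreadable from compound 2 to compound 3 cannot be read, and the limit of > 50000 nM in this assay, at which 2 of the 3 values shown sit, marks where two of the three values stand. Compound 4 `Cc1ccc(-n2nncc2CN2C(=O)C3(C(C#N)=C(N)Oc4c(N)cc5nc6ccccc6nc5c43)c3ccccc32)cc1Cl` differs from compound 3 in that (3-chloro-4-methylphenyl in place of 2,6-diethylphenyl on an aromatic nitrogen). With the steps of an at least 1.5-fold higher number from compound 1 to compound 2 (0.19 log units; that floor lies within the scatter) and an at least 1.5-fold higher number from compound 1 to compound 3 (0.19 log units; that floor lies within the scatter) no larger than their floors, compound 4 is expected to stay in the same weak region of this assay, with an expected step of an at least 1.2-fold lower number from compound 3 to compound 4 (0.09 log units; that floor lies within the scatter) that should not go beyond the scatter. Compound 4 is therefore estimated at 40000 nM, in a range from 15000 nM to 100000 nM.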

Compound 4, half-maximal inhibitory concentration: 11800 nM
Estimate against measurement, compound 4: 3.4-fold (0.53 log units) above; measured number below the stated range.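

In this assay, among these compounds, this position on the aromatic nitrogen now gives steps beyond the scatter, which no earlier step could show: 3-chloro-4-methylphenyl in place of 2,6-diethylphenyl gives an at least 4.2-fold lower number from compound 3 to compound 4 (0.62 log units; beyond the scatter), and in place of 4-acetamidophenyl it gives an at least 4.2-fold lower number from compound 2 to compound 4 (0.62 log units; beyond the scatter). Both sizes are floors, not full measures, and they rest on an assay limit: the limit of > 50000 nM in this assay, at which 2 of the 4 values shown sit.

Only the change from 2-methylphenyl has a fully readable size, a 2.7-fold lower number from compound 1 to compound 4 (0.43 log units; beyond the scatter), which shows that the group at this position can move the read-out between two real numbers.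

The compounds shown do not separate the chlorine from the methyl of 3-chloro-4-methylphenyl, so which of the two accounts for the step stays open. From the compounds shown here alone, how a phenyl bearing an amine or a carboxylic acid would behave at this position also remains open.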